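The source may report more compounds than this note shows. Statements on the series, on what has been measured and on what is new or still open speak of the compounds shown alone.

Series values in a functional assay on B16-F10 cells (Mus musculus) for antiproliferative activity, read by MTT assay, with a stated time of 72 h; a lower number here means a stronger inhibitor, a higher number a weaker inhibitor:

- compound 1 `CCCCCCCCCCNC[C@@H]1OC[C@H](N)[C@@H]1O`: 29600 nM
- compound 2 `CCCCCCCNC[C@@H]1OC[C@H](N)[C@@H]1O`: > 128000 nM (a limit of the assay)
- compound 3 `CCCCCCCCCCCCNC[C@@H]1OC[C@H](N)[C@H]1O`: 58100 nM

For the measured compounds named here, the numbers for compound 1 and compound 3 lie within the usual scatter of each other, and these two are the only numerical values in the set. Compound 3 therefore stands level with compound 1 in this assay. Compound 2 gives only a limit, > 128000 nM.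

Compound 4 `CCCCCCCCCNC[C@@H]1OC[C@H](N)[C@H]1O` is not yet measured. Its difference from compound 3 is hydrogen in place of propyl on a saturated chain carbon, nine bonds along the chain from an amine nitrogen.

Going by the values given here, one measured step bears on this change: an at least 4.3-fold higher number from compound 1 to compound 2 (0.63 log units; beyond the scatter). From the compounds shown here alone, it is the same exchange, made seven bonds along the chain from an amine nitrogen, and its true size stays open, as it ends at the limit of > 128000 nM in this assay, at which 1 of the 3 values shown sits. The core of compound 3 differs in spatial arrangement from that of compound 1, so the transfer is imperfect.

A weaker result is still expected, and a reading that reaches only the limit is quite possible. The estimate is a 2.6-fold higher number from compound 3 to compound 4 (0.41 log units; beyond the scatter). For compound 4 the expected value is 150000 nM, with an estimated range from 80000 nM to 300000 nM.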

Compound 4, half-maximal inhibitory concentration: > 128000 nM
Compound 4 gave a limit, no number; the forecaster's own chance of this, stated with the estimate: 60%; the middle value is on the limit's open side.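

On the second core, hydrogen in place of propyl on a saturated chain carbon, nine bonds along the chain from an amine nitrogen, gives an at least 2.2-fold higher number from compound 3 to compound 4 (0.34 log units; beyond the scatter) in this assay. The loss seen earlier at seven bonds along the chain therefore also appears on a core with a different spatial arrangement, and the direction of the step holds in both pairs, though the data do not fix the size of either step: the same change on two cores in this assay, an at least 4.3-fold higher number (0.63 log units; beyond the scatter) from compound 1 to compound 2 and an at least 2.2-fold higher number (0.34 log units; beyond the scatter) from compound 3 to compound 4; the limit leaves it open whether they differ

Compound 4 gives only a limit, and with it each core now has one member that yields no number in this assay, so the lower end of this series is bounded by the assay rather than measured: the limit of > 128000 nM in this assay, at which 2 of the 4 values shown sit.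

No pair shown differs only in the spatial arrangement of the core, so the contribution of that arrangement to the values cannot be read on its own. Also open, from the compounds shown here alone, is whether a longer chain on either core would lower the number further, and whether an amine or a carboxylic acid at the end of the chain would keep the values seen with the longer chains.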